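Thiosemicarbazide Hydrazones on a Shared Terpenoid Core

The compounds below may be only part of what the source reports. "The series", "measured", "known", "first", "only" and "open" are said of these compounds alone.

Measured compounds:
compound 1 `CC1=CC[C@@H]([C@@](C)(O)CCCC(C)(C)NC(=S)NN)CC1` gives 15300 nM in a functional assay on MCF7 cells (Homo sapiens) for cytotoxicity, read by sulforhodamine B assay; on this read-out higher numbers stand for weaker inhibition of growth and lower numbers for stronger inhibition of growth
compound 2 `CC1=CC[C@@H]([C@@](C)(O)CCCC(C)(C)NC(=S)N/N=C\c2ccc(Cl)cc2)CC1` gives 6890 nM in this assay

Within the data shown here, of the two numbers at hand, compound 2 holds the lower one, with compound 1 as its only neighbour; the distance between them is a 2.2-fold lower number from compound 1 to compound 2 (0.35 log units; beyond the scatter). Compound 3 `CC1=CC[C@@H]([C@@](C)(O)CCCC(C)(C)NC(=S)N/N=C(/C)c2ccccc2)CC1` is not yet measured. It differs from compound 2 by a group of 9 heavy atoms (8 carbon, 1 nitrogen; one six-membered aromatic ring of carbon only) in place of a group of 9 heavy atoms (7 carbon, 1 nitrogen, 1 chlorine; one six-membered aromatic ring of carbon only), on an amide-type nitrogen; in words, the chlorine-bearing aryl hydrazone of compound 2 gives way to an aryl hydrazone that carries an added carbon on its imine carbon and no chlorine.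

Among the measured compounds shown here, only one step bears on this change, a 2.2-fold lower number from compound 1 to compound 2 (0.35 log units; beyond the scatter), and it shows that installing an aryl hydrazone on the amide-type nitrogen moves the number modestly downward. The exchange of one such hydrazone for another is a smaller change than building the hydrazone in the first place, so for compound 3 the expected step is a 1.2-fold higher number from compound 2 to compound 3 (0.09 log units; within the scatter), which is a shift at or near the usual scatter. Compound 3 is therefore estimated at 8500 nM, within a range from 3500 nM to 21000 nM.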

Compound 3, concentration for 50% growth inhibition: 23600 nM
Compound 3: middle estimate off by 2.8-fold (0.44 log units), on the low side; the whole stated range lies below it.
By their numbers in this assay, from the lowest: compound 2; then compounds 1 and 3 (each within the scatter of the next).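

In this assay, the exchange of one aryl hydrazone for another on the amide-type nitrogen gives a 3.4-fold higher number from compound 2 to compound 3 (0.53 log units; beyond the scatter), so which hydrazone stands there matters and not merely that one does. An aryl hydrazone as such does not bring the number down: the hydrazone without chlorine shows a 1.5-fold higher number from compound 1 to compound 3 (0.19 log units; within the scatter), and the modest downward step first seen with the chlorine-bearing hydrazone is not shared by this one. Nothing at hand accounts for the difference between the two hydrazones.

Compound 3 differs from compound 2 both in lacking the chlorine and in carrying the added carbon on its imine carbon, so the compounds shown cannot say which of the two accounts for the step; the plain phenyl hydrazone without that carbon, or the chlorine-bearing hydrazone with it, would separate them. On these data alone, it also stays open whether a fluorine, a methoxy group or a nitro group on the aromatic ring would behave as the chlorine does.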